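This account rests on a few compounds, and the source may have more. Where it says the series, first, only, none or still open, it means among the compounds named here.

Series notes. Among the compounds with values here, compound 1 `Clc1cncc(N2CCCNCCC2)c1` was run in an assay on HEK293 cells with Neuronal acetylcholine receptor; alpha4/beta2 (Homo sapiens) as the target, read by FLIPR and calcium flux (on this read-out lower numbers stand for smaller maximal responses and higher numbers for larger maximal responses), and gave 103%, the lower of the two numbers measured so far. In this assay, within the data shown here, compound 2 `Brc1ccc(N2CCNCC2)cn1` gave 129%, a gap beyond the usual scatter; no single-point step links these two, so only their two values stand. Compound 3 `Brc1cncc(N2CCCNCCC2)c1` is still to be measured in this assay. It differs from compound 1 by bromo in place of chloro on an aromatic carbon. Among the measured compounds shown here, no measured step of this kind exists, so the step from compound 1 to compound 3 is expected to be small, probably none beyond the scatter: a number 5 percentage points higher from compound 1 to compound 3 (within the scatter) is the estimated change. Compound 3 is accordingly expected to reach 108%, with a range of 90% to 130%.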

Compound 3, largest response reached (reported as efficacy), in percent of the reference or control that the assay uses: 73%
Compound 3: middle estimate off by 35 percentage points, on the high side; the whole stated range lies above it.
By their numbers in this assay, from the lowest: compound 3; then compound 1; then compound 2.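

In this assay, within the data shown here, bromo in place of chloro gives a number 30 percentage points lower from compound 1 to compound 3 (beyond the scatter) and so sets the first single-point step. The position on the aromatic carbon two atoms from the ring nitrogen is therefore sensitive: exchanging one halogen atom for another, with no change in donors, acceptors or net charge, moves the maximal response beyond the scatter. Nothing at hand accounts for the size or direction of this step.

Open, on these data alone, is how fluoro, methyl or a nitrile on this carbon would read on the same core. One step also cannot show whether the same exchange gives a similar change on other cores.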